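The compounds below may be only part of what the source reports. "The series", "measured", "known", "first", "only" and "open" are said of these compounds alone.

Compound 1 `COc1ccc(N/C=C\C(=O)c2nc(-c3ccc(F)cc3)n3ccccc23)cc1OC` — in a functional assay on HCT-116 cells (Homo sapiens) for cytotoxicity, read by MTT assay, with a stated time of 48 h (a lower number here means a stronger inhibitor, a higher number a weaker inhibitor), compound 1 gives only a limit, > 30000 nM.
Compound 2 `O=C(/C=C\Nc1cnc2ccccc2c1)c1nc(-c2ccc(C(F)(F)F)cc2)n2ccccc12` — in this assay compound 2 likewise gives only a limit, > 30000 nM.
Compound 3 `COc1ccc(N/C=C\C(=O)c2nc(-c3ccccc3)n3ccccc23)cc1` — in this assay compound 3 gives a number, 7010 nM.

Compound 1 therefore stands at the limit of > 30000 nM in this assay, at which 2 of the 3 values shown sit, rather than at any measured number, and the same is true of compound 2. Compound 3 is the only one of the three with a numerical value, and that value is itself weak. Among the measured compounds shown here, no step between two measured compounds is available that shares one change with the one considered here.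

Compound 4 `O=C(/C=C\Nc1ccc(Cl)cc1)c1nc(-c2ccc(F)cc2)n2ccccc12` is the next compound, not yet measured in this assay. It differs from compound 1 in one place: 4-chlorophenyl in place of 3,4-dimethoxyphenyl on an amine nitrogen. Since compound 1 sits at a limit, the step to compound 4 cannot be measured against a number; it is only expected, and the expectation is for a modest step toward a stronger inhibitor, an at least 1.5-fold lower number from compound 1 to compound 4 (0.17 log units; that floor lies within the scatter), that may well leave compound 4 still at the limit. Compound 4 is estimated to give 20000 nM in this assay, with a range from 5000 nM to 40000 nM.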

Compound 4, half-maximal inhibitory concentration: 1210 nM
For compound 4 the middle estimate is 17-fold (1.22 log units) above the measured one; the measured number lies below the stated range.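

Placing 4-chlorophenyl instead of 3,4-dimethoxyphenyl on the amine nitrogen gives an at least 24-fold lower number from compound 1 to compound 4 (1.39 log units; beyond the scatter) in this assay. This is the first pair shown that differs in one place, and it shows that this position can carry a large change in the read-out while the rest of compound 1 stays as it is. The size of the step is only a floor and not a measured gap, because compound 1 stands at a limit: the limit of > 30000 nM in this assay, at which 2 of the 4 values shown sit.

The change removes both methoxy groups and brings in chlorine in a single swap, so the compounds shown do not separate the loss of the one from the gain of the other, and they do not show whether the same change would hold on a different core. From the compounds shown here alone, whether an unsubstituted phenyl, 4-bromophenyl or a ring carrying a dimethylamino group on the same amine nitrogen would match compound 4 also remains open.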